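A few compounds are considered here, and "the series" means these few. Any claim that something is new, unique, unknown or untested is made for them only; others in the source may bear on it.

Measured so far:
Compound 1 `COc1ccc(-c2cc(=O)c3c(OC)cc(OC)cc3n2C)cc1` — 28000 nM in a functional assay on SUP-B15 cells (Homo sapiens) for antiproliferative activity, with a stated time of 72 h; on this read-out higher numbers stand for an effect only at larger amounts of compound and lower numbers for an effect already at smaller amounts.
Compound 2 `COc1ccc(-c2cc(=O)c3c(OC)cc(OC)cc3n2Cc2ccccc2)cc1` — in this assay compound 2 gives only a limit, > 34400 nM.
Compound 3 `COc1ccc(-c2c(Br)c(=O)c3c(OC)cc(OC)cc3n2S(=O)(=O)c2ccc(OC)cc2)cc1` — 2920 nM in this assay.

Compound 3 holds the lowest of the two numbers in this assay; compound 1 sits higher by a gap beyond the scatter, and compound 2 contributes a limit.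

Compound 4 `COc1ccc(-c2c(I)c(=O)c3c(OC)cc(OC)cc3n2S(=O)(=O)c2ccc(OC)cc2)cc1` differs from compound 3 by iodo in place of bromo on an aromatic carbon. Going by the values given here, the single measured step, an at least 1.2-fold higher number from compound 1 to compound 2 (0.08 log units; that floor lies within the scatter), concerns a substituent on the ring nitrogen and ends at a limit (the limit of > 34400 nM in this assay, at which 1 of the 3 values shown sits); it does not bear on a halogen swap. Among the compounds with values here, with no step of this kind measured, compound 4 is expected to stay near compound 3, with no step beyond the scatter. The estimate for compound 4 in this assay is 2600 nM, within 900 nM to 7500 nM. The step this implies, a 1.1-fold lower number from compound 3 to compound 4 (0.05 log units; within the scatter), is expected to lie within the scatter.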

Compound 4, half-maximal effective concentration: 12300 nM
Compound 4: middle estimate off by 4.7-fold (0.67 log units), on the low side; measured number above the stated range.
By their numbers in this assay, from the lowest: compound 3; then compound 4; then compound 1. At a limit, above all of these: compound 2.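

In this assay, the halogen on this aromatic carbon matters: iodo in place of bromo gives (a 4.2-fold higher number from compound 3 to compound 4 (0.62 log units; beyond the scatter)), so the two halogens cannot be treated as interchangeable here. Until now, the only step shown concerned the substituent on the ring nitrogen, and that step ended at a limit, so this is the sole reading at this position. Nothing measured in the series accounts for the size of this step.

Open, going by these compounds, is how chloro or an amine on this carbon would read with the (4-methoxyphenyl)sulfonyl group kept in place. Also open, on these data alone, is whether either halogen improves on hydrogen at this position.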